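A few compounds are considered here, and "the series" means these few. Any claim that something is new, unique, unknown or untested is made for them only; others in the source may bear on it.

Measured compounds, with their results in a functional assay on A549 cells (Homo sapiens) for cytotoxicity, read by MTT assay, with a stated time of 24 h; on this read-out higher numbers stand for weaker inhibition and lower numbers for stronger inhibition:
compound 1, `CN(C)CCN1CCN(CC(=O)Nc2ccc(-c3nc4cc(Cl)ccc4o3)cc2)CC1`, gives 7100 nM
compound 2, `Cc1ccc2oc(-c3ccc(NC(=O)CN4CCN(CCN(C)C)CC4)cc3)nc2c1`, gives 3660 nM
compound 3, `Cc1cc(-c2nc3cc(Cl)ccc3o2)ccc1NC(=O)CCl`, gives 91500 nM

Compound 1 and compound 2 share one core; compound 3 is built on a different core, and the difference between the two cores is not broken down here. Within the first pair the change is methyl in place of chloro on an aromatic carbon, and it made the step of a 1.9-fold lower number from compound 1 to compound 2 (0.29 log units; within the scatter). Compound 3 stands with the highest number of the three, far above both compound 1 and compound 2 on this read-out.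

Compound 4, `Cc1ccc2oc(-c3ccc(NC(=O)CCl)c(C)c3)nc2c1`, is not yet measured. It arises from compound 3 by methyl in place of chloro on an aromatic carbon, the same change at the same place as in the pair above, so this change now occurs twice among the compounds shown. Because the earlier instance gave a 1.9-fold lower number from compound 1 to compound 2 (0.29 log units; within the scatter), a step of similar size is expected, namely a 1.7-fold lower number from compound 3 to compound 4 (0.22 log units; within the scatter). In this assay compound 4 is estimated at 55000 nM, with a range of 20000 nM to 150000 nM.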

Compound 4, half-maximal inhibitory concentration: 61800 nM
Compound 4: middle estimate off by 1.1-fold (0.05 log units), on the low side; low and high end bracket the measured number.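

In this assay, methyl in place of chloro on an aromatic carbon gives a 1.5-fold lower number from compound 3 to compound 4 (0.17 log units; within the scatter), and this step matches the earlier one, so the change carries from one core to the other without a visible difference: the same change on two cores in this assay, a 1.9-fold lower number (0.29 log units; within the scatter) from compound 1 to compound 2 and a 1.5-fold lower number (0.17 log units; within the scatter) from compound 3 to compound 4, 1.3-fold (0.12 log units) apart, within the scatter of two such steps.
Both steps lie within the scatter, so what carries over is the absence of a clear effect, and the two compounds of each pair cannot be told apart on this read-out.
This does not show that the change would behave alike on further cores or in other cells, since the comparison rests on two cores and one assay, and it gives no reason for the match.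

Other groups on the same aromatic carbon, such as fluoro, methoxy or nitrile, remain open, as does a plain hydrogen there. Also open, going by these compounds, is how much of the gap between the two cores belongs to the side chain and how much to the ring methyl of compound 3 and compound 4, as the cores differ in more than one place.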